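The source may report more compounds than this note shows. Statements on the series, on what has been measured and on what is new or still open speak of the compounds shown alone.

Working notes on the series in an assay on HL-60 cells for agonist activity at N-formyl peptide receptor 3 (Homo sapiens), read by calcium flux; on this read-out lower numbers stand for an effect already at smaller amounts and higher numbers for an effect only at larger amounts of compound. Compound 1 `COc1cccc(Cc2cc(-c3ccccc3)nn(CC(=O)Nc3ccc(Br)cc3)c2=O)c1` is reported only as a limit of the assay, > 50000 nM. Compound 2 `COc1ccc(Cc2cc(Cc3ccccc3)nn(CC(=O)Nc3ccc(Br)cc3)c2=O)cc1` likewise reaches only a limit, > 50000 nM. Compound 3 `Cc1cc(Cc2cccc(Br)c2)c(=O)n(CC(=O)Nc2ccc(Br)cc2)n1` again gives no number in this assay but the limit > 50000 nM. Compound 3 therefore stands nowhere in particular on the numbers shown: there is no measured value for it, only a limit, and the same holds for the other two compounds, as the limit of > 50000 nM in this assay, at which 3 of the 3 values shown sit, states. For the measured compounds named here, no pair of measured compounds differs in one place, so no measured step exists from which a trend could be read.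

Compound 4 `Cc1cc(Cc2ccc(C(N)=O)cc2)c(=O)n(CC(=O)Nc2ccc(Br)cc2)n1` is the next compound to be measured in this assay. It differs from compound 3 in a single change, (4-carbamoylphenyl in place of 3-bromophenyl on a saturated chain carbon bound to an aromatic carbon), that is, 4-carbamoylphenyl in place of 3-bromophenyl on a saturated chain carbon bound to an aromatic carbon. Since every value in the series sits at the limit, no direction can be drawn from the data; the expected step that the limit leaves unreadable from compound 3 to compound 4 is none beyond the scatter, with the result most likely again a limit. The estimate for compound 4 in this assay is 60000 nM, expected to fall between 15000 nM and 250000 nM.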

Compound 4, half-maximal effective concentration: > 50000 nM
Compound 4: no number, only a limit (the forecaster's own chance of this, stated with the estimate: 75%); the middle value is on the limit's open side.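

Compound 3 and compound 4 both stand only as limits in this assay, so no step between them can be read: the limit of > 50000 nM in this assay, at which 4 of the 4 values shown sit.

The compounds shown leave open whether any change on the shared core yields a countable effect in this assay.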